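A few compounds are considered here, and "the series" means these few. Any claim that something is new, unique, unknown or untested is made for them only; others in the source may bear on it.

Compound 1 `Cc1ccc(-c2cccc(S(=O)(=O)N3CCC(N4CCC(C)CC4)CC3)c2)cc1` was examined in an ADME assay on S9 fraction from liver (Mus musculus, strain ICR/CD-1) for metabolic stability, read by LC-MS, using NADPH, with a stated time of 5 min, tested at 2 uM (a higher number here means that the compound lasts longer, a lower number that the compound disappears faster), where compound 1 gives 1.92 h. Among the two compounds measured so far this is the lower number: compound 2 `COc1ccccc1-c1ccc(S(=O)(=O)N2CCC(N3CCC(C)CC3)CC2)cc1` gives 4.82 h in this assay, and the gap between the two lies beyond the scatter of repeated measurements. For the measured compounds named here, no single-point step between measured compounds is available, so the effect of trimming the outer ring has to be judged from the structures alone. Compound 3 `CC1CCN(C2CCN(S(=O)(=O)c3cccc(-c4ccccc4)c3)CC2)CC1` differs from compound 1 in one place only: hydrogen in place of methyl on an aromatic carbon. The step from compound 1 to compound 3 in this assay is expected to be small, with the estimated step of a 1.3-fold higher number from compound 1 to compound 3 (0.11 log units; within the scatter) most likely falling within the usual scatter, though a mild lengthening of the half-life would not be surprising. Compound 3 is therefore expected to give about 2.5 h in this assay, within a range from 1.2 h to 5 h.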

Compound 3, half-life: 0.517 h
Beside the measured number, compound 3's estimate is 4.8-fold (0.68 log units) above it; the whole stated range lies above it.
By their numbers in this assay, from the lowest: compound 3; then compound 1; then compound 2.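

In this assay, for the compounds shown here, the exchange of methyl for hydrogen gives a 3.7-fold lower number from compound 1 to compound 3 (0.57 log units; beyond the scatter) and so ties a change in half-life to a single place for the first time, which the two earlier compounds could not do. This aromatic carbon, para to a large group, is therefore not a silent position: the half-life is longer with the methyl present, and the 4-methylphenyl to phenyl change shortens it beyond the scatter. Nothing available here accounts for why the methyl goes with the longer half-life.

The compounds shown do not tell whether this is particular to methyl or would also hold for a chlorine atom, a methoxy group or an ethyl chain on the same carbon. Nor do they show whether the same exchange would give a step of this size on the core of compound 2.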